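Compound 2 to compound 4: swapping the trifluoromethyl group

The source may report more compounds than this note shows. Statements on the series, on what has been measured and on what is new or still open speak of the compounds shown alone.

In an ADME assay on microsomes from liver (Homo sapiens) for metabolic stability, using NADPH, with a stated time of 40 min, tested at 2 uM (a lower number here means that the compound disappears faster, a higher number that the compound lasts longer), compound 2 (`Fc1cc2c(-c3ccc4c(C(F)(F)F)cccc4n3)c[nH]c2c(F)c1F`) gives 1.12 h. Compound 3 (`Cc1cc(C)c2[nH]cc(-c3ccc4ccccc4n3)c2c1`) gives 1.57 h, which lies within the scatter of compound 2, so these two sit together at the upper end of the three numbers available. Compound 1 (`Fc1cc(F)c2[nH]cc(-c3ccc4ccccc4n3)c2c1`) gives 0.45 h, lower than compound 2 by more than the scatter.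

Compound 4 (`CNC(=O)c1cccc2nc(-c3c[nH]c4c(F)c(F)c(F)cc34)ccc12`) has methylcarbamoyl in place of trifluoromethyl on an aromatic carbon, and the rest of the structure of compound 2 is kept: methylcarbamoyl in place of trifluoromethyl on an aromatic carbon.

Among the compounds with values here, no two measured compounds differ in one place only, so the series offers no direct measure of this or any other single change. The three values also differ in more than one place at a time, and they give no sound basis for a direction. Compound 2, at 1.12 h, is therefore the only anchor, and a step beyond the scatter is not expected in either direction, with a slight rise as the working guess. The expected step is a 1.3-fold higher number from compound 2 to compound 4 (0.10 log units; within the scatter), which is an estimate within the scatter. Within the data shown here, the range is kept wide because no single-change precedent exists. The estimate for compound 4 is 1.4 h, with an expected range from 0.6 h to 3.5 h.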

Compound 4, half-life: 1.17 h
Beside the measured number, compound 4's estimate is 1.2-fold (0.08 log units) above it, within the range that was stated.
By their numbers in this assay, from the lowest: compound 1; then compounds 2, 4 and 3 (each within the scatter of the next).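

In this assay, within the data shown here, methylcarbamoyl in place of trifluoromethyl gives a 1.0-fold higher number from compound 2 to compound 4 (0.02 log units; within the scatter), and this is the first comparison that differs in one place only. On this aromatic carbon, ortho to a fused ring and meta to a fused ring, the half-life therefore does not separate the two groups beyond the scatter, even though methylcarbamoyl carries a hydrogen-bond donor and a hydrogen-bond acceptor that trifluoromethyl lacks. Nothing on hand accounts for this result, so it stands as an observation on one pair of compounds and gives no explanation.

On these data alone, whether this position accepts other groups equally well remains open, for instance a nitrile, a carboxylic acid, an amine or an amide with a longer chain on its nitrogen. As far as these compounds go, it is also open whether methylcarbamoyl in place of trifluoromethyl would give a step of the same size on the core of compound 1 or the core of compound 3, since a single pair cannot show how far this result carries over to other substitution on the shared core.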